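Adding 4-methoxyphenyl to compound 2

The compounds below may be only part of what the source reports. "The series", "measured", "known", "first", "only" and "open" are said of these compounds alone.

Measured in a functional assay on PC-3 cells (Homo sapiens) for cytotoxicity, read by WST assay, with a stated time of 24 h (on this read-out lower numbers stand for stronger inhibition and higher numbers for weaker inhibition), so far
Compound 1 `COc1ccc2c(/C=C(\C#N)C(=O)c3c[nH]c4ccccc34)c[nH]c2c1` gives 33300 nM
Compound 2 `N#C/C(=C\c1c[nH]c2ccccc12)C(=O)c1c[nH]c2ccccc12` gives > 50000 nM (a limit)

Compound 2 stands at > 50000 nM as a limit and not a number. Compound 3 `COc1ccc(-c2[nH]c3ccccc3c2/C=C(\C#N)C(=O)c2c[nH]c3ccccc23)cc1` carries 4-methoxyphenyl in place of hydrogen on an aromatic carbon. Among the compounds with values here, the only measured step is a different change, hydrogen in place of methoxy (an at least 1.5-fold higher number from compound 1 to compound 2 (0.17 log units; that floor lies within the scatter)), so it sets no size for this one. Compound 1 at 33300 nM is the nearest number, and a moderate move to a lower number is expected. The estimated move is an at least 2.7-fold lower number from compound 2 to compound 3 (0.44 log units; beyond the scatter) in this assay and remains uncertain. For compound 3 the expected value is 18000 nM with an estimated range from 4000 nM to 60000 nM in this read-out.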

Compound 3, half-maximal inhibitory concentration: 17200 nM
Estimate against measurement, compound 3: 1.0-fold (0.02 log units) above, within the range that was stated.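

In this assay, 4-methoxyphenyl in place of hydrogen on the aromatic carbon next to the ring nitrogen gives an at least 2.9-fold lower number from compound 2 to compound 3 (0.46 log units; beyond the scatter). This is the first change at this position among the compounds shown, and the first step that clearly lies beyond the scatter. Its size is only a floor because compound 2 stands at a limit: the limit of > 50000 nM in this assay, at which 1 of the 3 values shown sits.

As far as these compounds go, it remains open whether the aromatic ring alone or its methoxy carries this move. From the compounds shown here alone, it is also open whether a plain phenyl, an amine or a carboxylic acid on this carbon would shift the number likewise.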